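Pyridyl imidazolidinone series: tolerance, chloro to trifluoromethyl step

The compounds below may be only part of what the source reports. "The series", "measured", "known", "first", "only" and "open" are said of these compounds alone.

Measured so far:
compound 1, `O=C1N(CCCCCCOc2ccc(C(F)(F)F)cc2)CCN1c1ccnc(Cl)c1`: > 25000 nM
compound 2, `O=C1N(CCCCCCOc2ccc(Cl)cc2)CCN1c1cccnc1`: > 25000 nM

In a functional assay on cells (Homo sapiens) for cytotoxicity (a higher number here means that more compound is tolerated, a lower number that less compound is tolerated), compound 1 reaches only a limit, > 25000 nM. In this assay compound 2 likewise reaches only a limit, > 25000 nM. Going by the values given here, compound 2 therefore has no number of its own to stand on; the one further value shown is also a limit, namely (the limit of > 25000 nM in this assay, at which 2 of the 2 values shown sit). Among the compounds with values here, no step between measured compounds can be computed from two limits.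

Compound 3, `O=C1N(CCCCCCOc2ccc(C(F)(F)F)cc2)CCN1c1cccnc1`, differs from compound 2 by trifluoromethyl in place of chloro on an aromatic carbon. Compound 1 already carries that trifluoromethyl group and sits at the limit as well. For the step from compound 2 to compound 3 no shift beyond the scatter is expected, and a step that the limit leaves unreadable from compound 2 to compound 3 is the estimated size. Compound 3 is expected to come out at 40000 nM, with a range from 20000 nM to 100000 nM, most likely again as a limit rather than a number.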

Compound 3, half-maximal cytotoxic concentration: > 25000 nM
Compound 3: only a limit was reported; the forecaster's own chance of this, stated with the estimate: 85%; the middle value is on the limit's open side.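

In this assay, the steps from compound 2 and from compound 1 to compound 3 cannot be read, because all three compounds stop at the same limit: the limit of > 25000 nM in this assay, at which 3 of the 3 values shown sit. The compounds shown leave open how far each one lies past that limit, and whether trifluoromethyl in place of chloro or pyridin-3-yl in place of 2-chloropyridin-4-yl shifts tolerance at all.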